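This account rests on a few compounds, and the source may have more. Where it says the series, first, only, none or still open, it means among the compounds named here.

Measured so far in an assay on isolated protein for binding affinity to 5-hydroxytryptamine receptor 5A (Homo sapiens); on this read-out lower numbers stand for stronger inhibition and higher numbers for weaker inhibition:
- compound 1 `COc1ccccc1-c1cc(C2CCNC2)ccc1Cl` gives 970 nM
- compound 2 `CCCCNCc1ccc(Cl)c(-c2ccccc2OC)c1` gives 360 nM

Compound 2 stands at the lower of the two numbers, with a 2.7-fold lower number from compound 1 to compound 2 (0.43 log units; beyond the scatter) separating it from compound 1. Compound 3 `CCN(CC)Cc1ccc(Cl)c(-c2ccccc2OC)c1` is not yet measured; it differs from compound 2 by diethylamino in place of butylamino on a saturated chain carbon bound to an aromatic carbon. Going by the values given here, no measured step covers this kind of change: the only step in hand, a 2.7-fold lower number from compound 1 to compound 2 (0.43 log units; beyond the scatter), exchanges a ring for an open chain amine and does not bear on it. For compound 3 the step is therefore expected to be a 1.4-fold higher number from compound 2 to compound 3 (0.14 log units; within the scatter), that is, nothing beyond the scatter with either direction open. In this assay compound 3 is estimated at 500 nM, within 150 nM to 1600 nM.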

Compound 3, inhibition constant: 230 nM
Compound 3: middle estimate off by 2.2-fold (0.34 log units), on the high side; low and high end bracket the measured number.
By their numbers in this assay, from the lowest: compounds 3 and 2 (each within the scatter of the next); then compound 1.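

In this assay, diethylamino in place of butylamino on a saturated chain carbon bound to an aromatic carbon removes the one hydrogen-bond donor of that group, yet the result is a 1.6-fold lower number from compound 2 to compound 3 (0.19 log units; within the scatter), so losing this donor brings no change that can be told from the scatter. A second open chain amine also separates from pyrrolidin-3-yl, with a 4.2-fold lower number from compound 1 to compound 3 (0.63 log units; beyond the scatter), so the gap to compound 1 is not confined to butylamino.

Open, going by these compounds, is whether dimethylamino or a piperidine ring on the same carbon stays at this level in this assay. Nothing in hand explains these numbers.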